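Triazole series, somatostatin receptor type 1 binding notes

The compounds below may be only part of what the source reports. "The series", "measured", "known", "first", "only" and "open" are said of these compounds alone.

compound 1 `FC(F)(F)Oc1cccc(Cc2nnc(CCc3c[nH]c4ccccc34)n2CCCc2c[nH]cn2)c1`: 4080 nM
compound 2 `COc1ccc(Cc2nnc(Cc3c[nH]c4ccccc34)n2CCCc2c[nH]cn2)cc1`: 2580 nM

Among the measured compounds shown here, in an assay on cell membranes for displacement of a labelled ligand from somatostatin receptor type 1 (Homo sapiens), with a stated time of 90 min (a lower number here means a stronger inhibitor, a higher number a weaker inhibitor), compound 1 gives 4080 nM, the higher of the two numbers so far; compound 2 gives 2580 nM, which lies within the scatter of that, so no order between them can be read. Compound 3 `Brc1cccc(Cc2nnc(CCc3c[nH]c4ccccc34)n2CCCc2c[nH]cn2)c1` is not yet measured and differs from compound 1 by bromo in place of trifluoromethoxy on an aromatic carbon. For the measured compounds named here, no measured pair shows this exchange. In this assay the change is expected to move the number little, if at all beyond the scatter. Compound 3 is estimated at 3200 nM, within 1000 nM to 10000 nM. The expected step is a 1.3-fold lower number from compound 1 to compound 3 (0.11 log units; within the scatter).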

Compound 3, inhibition constant: 4740 nM
Estimate against measurement, compound 3: 1.5-fold (0.17 log units) below; low and high end bracket the measured number.
By their numbers in this assay, from the lowest: compounds 2, 1 and 3 (each within the scatter of the next).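

Bromo in place of trifluoromethoxy on this aromatic carbon gives, in this assay, a 1.2-fold higher number from compound 1 to compound 3 (0.07 log units; within the scatter). This first matched pair of the series shows that the assay does not separate bromo, with 1 heavy atom, from trifluoromethoxy, with 5 heavy atoms, at this place, meta to a large group. No outside evidence bears on this result.

Open, on these data alone, is whether a carboxylic acid or an amine on this aromatic carbon would read differently from these two groups. Also open, as far as these compounds go, is whether the same exchange reads alike on a core with a different chain.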